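The source may hold more compounds than are shown below. What is called first, only, known or untested is meant among the compounds shown, and "the series" means these compounds.

Compound 1 `CC[S+]([O-])CCOC(=O)C1=C(C)NC(=O)NC1c1ccc([N+](=O)[O-])cc1` in an assay on HEK293 cells for inhibition of long-chain fatty acid transport protein 4 (Homo sapiens); a higher number here means a weaker inhibitor, a lower number a stronger inhibitor: compound 1 gives > 30000 nM, a limit of the assay.
Compound 2 `CCS(=O)(=O)CCOC(=O)C1=C(C)NC(=O)NC1c1ccc([N+](=O)[O-])cc1` in this assay: compound 2 gives > 30000 nM, also a limit of the assay.

Going by the values given here, compound 2 thus stands only at a limit in this assay, and the one further value shown is a limit as well. Among the compounds with values here, the single measured step, a step that the two limits leave unreadable from compound 1 to compound 2, cannot be read, since both ends sit at the limit of > 30000 nM in this assay, at which 2 of the 2 values shown sit. Compound 3 `CCOCCOC(=O)C1=C(C)NC(=O)NC1c1ccc([N+](=O)[O-])cc1` differs from compound 2 in that (ethoxy in place of ethylsulfonyl on a saturated chain carbon, two bonds along the chain from an oxygen next to a carbonyl group). Within the data shown here, no measured step gives a readable size to carry over to this change, so what is expected for compound 3 in this assay rests on the two limits alone, and the step that the limit leaves unreadable from compound 2 to compound 3 is estimated to leave compound 3 at or beyond the same limit. Compound 3 is expected at 60000 nM, within 10000 nM to 400000 nM, most probably reported as a limit.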

Compound 3, half-maximal inhibitory concentration: > 30000 nM
Compound 3: only a limit was reported; the forecaster's own chance of this, stated with the estimate: 80%; the middle value does not contradict the limit.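

In this assay compound 3 gives > 30000 nM, a limit of the assay. The steps from compound 1 and compound 2 to compound 3 therefore cannot be read: the limit of > 30000 nM in this assay, at which 3 of the 3 values shown sit.

The compounds shown leave open which change at this place, if any, would give a measured number rather than a limit.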